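The source may hold more compounds than are shown below. What is called first, only, known or untested is meant among the compounds shown, and "the series" means these compounds.

Measured compounds:
- compound 1 `O=C1/C(=C/c2ccccc2F)CN(S(=O)(=O)c2ccc(Br)cc2)C/C1=C\c1ccccc1F`: 13700 nM in a functional assay on HepG2 cells (Homo sapiens) for cytotoxicity, read by MTT assay, with a stated time of 24 h; a lower number here means a stronger inhibitor, a higher number a weaker inhibitor
- compound 2 `N#Cc1ccc(S(=O)(=O)N2C/C(=C\c3ccccc3F)C(=O)/C(=C/c3ccccc3F)C2)cc1`: 16500 nM in this assay

Among these two numbers, compound 2 carries the larger figure, its only neighbour being compound 1; the step of a 1.2-fold higher number from compound 1 to compound 2 (0.08 log units; within the scatter) is small enough that the two compounds cannot be told apart.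

The next compound, compound 3 `CC(=O)Nc1ccc(S(=O)(=O)N2C/C(=C\c3ccccc3F)C(=O)/C(=C/c3ccccc3F)C2)cc1`, keeps the whole core of compound 2 and changes only the substituent on the phenylsulfonyl ring: acetamido in place of cyano on an aromatic carbon. For the measured compounds named here, the one measured step that bears on this change is the exchange at the same place from compound 1 to compound 2, a 1.2-fold higher number from compound 1 to compound 2 (0.08 log units; within the scatter), which stayed within the scatter. With a single such step to go on, and that one flat, there is no ground to expect movement in this assay beyond the scatter in either direction; the expected step is a 1.0-fold higher number from compound 2 to compound 3 (0.01 log units; within the scatter). Compound 3 is therefore estimated at 17000 nM, with a range from 7000 nM to 40000 nM.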

Compound 3, half-maximal inhibitory concentration: 5200 nM
Compound 3: the middle estimate sits 3.3-fold (0.51 log units) above what was measured; measured number outside the range, below it.
By their numbers in this assay, from the lowest: compound 3; then compounds 1 and 2 (each within the scatter of the next).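

In this assay, the aromatic carbon para to a large group turns out not to be indifferent to what it carries: the exchange of cyano for acetamido gives a modest change beyond the scatter (a 3.2-fold lower number from compound 2 to compound 3 (0.50 log units; beyond the scatter)), and that of bromo for acetamido gives another (a 2.6-fold lower number from compound 1 to compound 3 (0.42 log units; beyond the scatter)). The only earlier step at this place, between bromo and cyano, had stayed flat (a 1.2-fold higher number from compound 1 to compound 2 (0.08 log units; within the scatter)), so among these three compounds the position responds to one exchange and not to the other, with compound 3 standing apart from the two others, which cannot be told apart. Acetamido brings more heavy atoms than cyano and, unlike cyano, a hydrogen-bond donor, but no measurement at hand ties either difference to the lower number.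

The compounds shown leave open whether the shift depends on the amide hydrogen or on the acetamido group as a whole, which a free amine, a tertiary amide or a longer acyl chain such as propionamido on the same carbon could help to separate. They also leave open whether the same exchange would move the number in the same direction if the two 2-fluorophenyl groups of the shared core gave way to other aryl groups.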